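Heteroaryl swap on the chain carbon: outlook for compound 4

The source may hold more compounds than are shown below. What is called first, only, known or untested is meant among the compounds shown, and "the series" means these compounds.

Measured so far:
- compound 1, `CC(C)C(c1nnc[nH]1)c1ccc(-c2ccc3cccc(F)c3c2)[nH]c1=O`: in an ADME assay on microsomes from liver (Rattus norvegicus) for metabolic stability (on this read-out lower numbers stand for a shorter-lived compound and higher numbers for a longer-lived compound), compound 1 gives 0.552 h.
- compound 2, `CC(C)NC(=O)CC(c1ccc(-c2ccc3cccc(F)c3c2)[nH]c1=O)C(C)C`: in this assay compound 2 gives only a limit, < 0.0667 h.
- compound 3, `CC(C)C(Cc1nnn[nH]1)c1ccc(-c2ccc3cccc(F)c3c2)[nH]c1=O`: in this assay compound 3 gives 2.08 h.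

Compound 1 sits lowest of the two numbers; its nearest neighbour is compound 3, reached by a 3.8-fold higher number from compound 1 to compound 3 (0.58 log units; beyond the scatter). Compound 2 sits at a limit of the assay, (the limit of < 0.0667 h in this assay, at which 1 of the 3 values shown sits), so its step from compound 1 is an at least 8.2-fold lower number from compound 1 to compound 2 (0.91 log units; beyond the scatter), a lower bound only.

Compound 4, `Cc1c[nH]c(C(c2ccc(-c3ccc4cccc(F)c4c3)[nH]c2=O)C(C)C)n1`, differs from compound 1 at the same position that both measured steps touch: 4-methyl-1H-imidazol-2-yl in place of 4H-1,2,4-triazol-3-yl on a saturated chain carbon bound to an aromatic carbon and a saturated chain carbon. The two prior replacements of the 4H-1,2,4-triazol-3-yl go in opposite directions: the (1H-tetrazol-5-yl)methyl raises the half-life modestly, the (isopropylcarbamoyl)methyl lowers it at least modestly. Compound 4 keeps a five-membered aromatic ring with a hydrogen-bond donor, so it is expected to stay closer to compound 1 than to compound 2, with the expected step of a 1.2-fold lower number from compound 1 to compound 4 (0.09 log units; within the scatter) lying within the scatter. The half-life of compound 4 in this assay is estimated at 0.45 h, with a range from 0.15 h to 1.3 h.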

Compound 4, half-life: < 0.0667 h
Compound 4: a limit, no number; the forecaster's own chance of this, stated with the estimate: 10%; middle value at least 6.7-fold (0.82 log units) from the limit.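

In this assay compound 4 gives only a limit, the same limit as compound 2: the limit of < 0.0667 h in this assay, at which 2 of the 4 values shown sit. A five-membered aromatic ring with a hydrogen-bond donor on this saturated chain carbon is therefore not enough to keep the half-life: 4-methyl-1H-imidazol-2-yl in place of 4H-1,2,4-triazol-3-yl gives an at least 8.2-fold lower number from compound 1 to compound 4 (0.91 log units; beyond the scatter), and in place of (1H-tetrazol-5-yl)methyl it gives an at least 31-fold lower number from compound 3 to compound 4 (1.49 log units; beyond the scatter). The step between compound 2 and compound 4 cannot be read, as both values are limits.

The compounds shown do not separate the added methyl from the change in ring nitrogens, since the two differences arrive together in compound 4. An unsubstituted 1H-imidazol-2-yl on the same chain carbon would divide them, and a 1H-tetrazol-5-yl there would test whether the methylene of compound 3 matters.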